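The compounds below may be only part of what the source reports. "The series", "measured", "known", "first", "only" and "open" are said of these compounds alone.

In a functional assay on MDA-MB-231 cells (Homo sapiens) for antiproliferative activity, read by MTT assay, with a stated time of 72 h (on this read-out lower numbers stand for stronger inhibition and higher numbers for weaker inhibition), compound 1 (`CCCn1ccnc1-c1cc(OC)c(OC)c(OC)c1`) gives > 100000 nM, which is a limit and not a number. Compound 2 (`COc1cc(-c2nccn2CC(C)C)cc(OC)c1OC`) gives > 100000 nM, also only a limit, and so stands at the limit of > 100000 nM in this assay, at which 2 of the 2 values shown sit. Compound 3 (`CCCCCn1ccnc1-c1cc(OC)c(OC)c(OC)c1`) has butyl in place of isopropyl on a saturated chain carbon bound to an aromatic nitrogen. Within the data shown here, the only measured step, a step that the two limits leave unreadable from compound 1 to compound 2, gives no size to carry over, so no shift beyond the scatter is expected in this assay. The estimated change is a number no higher from compound 2 to compound 3 (the limit leaves the size open). For compound 3 the expected value is 100000 nM, with an estimated range of 30000 nM to 300000 nM.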

Compound 3, half-maximal inhibitory concentration: 34200 nM
Compound 3: middle estimate off by 2.9-fold (0.47 log units), on the high side; the measured number falls inside the stated range.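

In this assay the chain on the aromatic nitrogen proves able to move the read-out, with an at least 2.9-fold lower number from compound 2 to compound 3 (0.46 log units; beyond the scatter) and an at least 2.9-fold lower number from compound 1 to compound 3 (0.46 log units; beyond the scatter) on going to the pentyl chain. Both sizes are lower bounds, and the step between compound 1 and compound 2 cannot be read. Only compound 3 has a number, while the other two remain at a limit of the assay: the limit of > 100000 nM in this assay, at which 2 of the 3 values shown sit.

As far as these compounds go, whether a longer chain such as hexyl lowers the number further remains open. So does the effect of an amine at the end of the chain.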